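Removing the Hydroxy Group from Compound 3

The source may hold more compounds than are shown below. What is called first, only, known or untested is meant among the compounds shown, and "the series" means these compounds.

Compound 3 `CNC(=O)c1cc(C(=O)N[C@H]2C[C@@H]2C)cc2c1OC[C@@]2(CO)c1ccccc1` gives 3.3 in a physicochemical assay for lipophilicity, at pH 7.4 (a lower number here means a more polar compound, a higher number a more lipophilic compound), the lowest of the three numbers measured. Compound 1 `CNC(=O)c1cc(C(=O)NC)c2c(c1)[C@](C)(c1ccccc1)CO2` stands nearest to it with 3.4, within the scatter, and compound 2 `CNC(=O)c1cc(C(=O)NC2CC2)cc2c1OC[C@@]2(C)c1ccccc1` stands furthest with 4, beyond the scatter. Going by the values given here, the one measured step in a single place, a number 0.60 log units higher from compound 1 to compound 2 (beyond the scatter), is modest and concerns a cyclopropyl in place of methyl on an amide-type nitrogen. Compound 4 `CNC(=O)c1cc(C(=O)N[C@H]2C[C@@H]2C)cc2c1OC[C@@]2(C)c1ccccc1` differs from compound 3 in another way: hydrogen in place of hydroxy on a saturated chain carbon bound to a saturated ring carbon. Among the compounds with values here, no measured pair bears directly on that change. Compound 2 and compound 3 differ in two places, and their numbers show the compound carrying a methyl well above the one carrying a hydroxymethyl. Because compound 2 gives 4 in this assay, the step is expected to go upward and beyond the scatter. Compound 4 is therefore estimated to give 4.4, between 3.9 and 4.9. The expected step is a number 1.10 log units higher from compound 3 to compound 4 (beyond the scatter).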

Compound 4, distribution coefficient: 4.7
Compound 4: the middle estimate sits 0.30 log units below what was measured; low and high end bracket the measured number.
By their numbers in this assay, from the lowest: compounds 3 and 1 (each within the scatter of the next); then compound 2; then compound 4.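

Hydrogen in place of hydroxy on a saturated chain carbon bound to a saturated ring carbon now has a direct reading in this assay: the large step is a number 1.40 log units higher from compound 3 to compound 4 (beyond the scatter) and it stands on a single change, where earlier only a pair differing in two places touched this position. The amide-type nitrogen gains two readings as well, with methyl in place of hydrogen on a saturated ring carbon giving a number 0.70 log units higher from compound 2 to compound 4 (beyond the scatter) and 2-methylcyclopropyl in place of methyl giving a number 1.30 log units higher from compound 1 to compound 4 (beyond the scatter) as a large step, so that methyl, cyclopropyl and 2-methylcyclopropyl rise in that order across these three compounds, with none going against it. Nothing at hand explains why these numbers move as they do.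

The compounds shown leave open how an amine or a carboxylic acid in place of the hydroxy on that chain carbon would read. They also leave open whether the hydroxymethyl to methyl step keeps its size with another group on the amide-type nitrogen, since it is read only with 2-methylcyclopropyl there.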